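Cytotoxicity of amide variants on a shared imidazole-free core

This account rests on a few compounds, and the source may have more. Where it says the series, first, only, none or still open, it means among the compounds named here.

Measured compounds:
Compound 1, `COc1ccc(-c2cnc(NC(=O)c3ccn[nH]3)n2C)cc1`: in a toxicity assay on THP-1 cells (Homo sapiens) for inhibition (a higher number here means that more compound is tolerated, a lower number that less compound is tolerated), compound 1 gives > 100000 nM, a limit of the assay.
Compound 2, `CCCC(=O)Nc1ncc(-c2ccc(OC)cc2)n1C`: in this assay compound 2 gives > 100000 nM, again a limit.
Compound 3, `COc1ccc(-c2cnc(NC(=O)c3cccc(C)c3)n2C)cc1`: in this assay compound 3 gives > 100000 nM, also a limit.

For the measured compounds named here, compound 3 therefore stands where every measured compound stands: at the limit, with no number of its own, and no compound can be ranked against another because the limit of > 100000 nM in this assay, at which 3 of the 3 values shown sit, holds all three values.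

The step under consideration leads to compound 4, `COc1ccc(-c2cnc(NC(=O)c3ccccc3Cl)n2C)cc1`. The change is 2-chlorophenyl in place of 3-methylphenyl on a carbonyl carbon.

Going by the values given here, three measured steps touch the same carbonyl carbon. From compound 1 to compound 2 the step is a step that the two limits leave unreadable from compound 1 to compound 2, from compound 1 to compound 3 it is a step that the two limits leave unreadable from compound 1 to compound 3, and from compound 2 to compound 3 it is a step that the two limits leave unreadable from compound 2 to compound 3. Each is unreadable, because both ends sit at the limit of > 100000 nM in this assay, at which 3 of the 3 values shown sit. Among the compounds with values here, they show only that swapping the group on this carbonyl carbon among a pyrazole, a propyl chain and a methylated phenyl never brought a measurable toxicity.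

Replacing 3-methylphenyl with 2-chlorophenyl on the same carbonyl carbon is expected to leave this assay unchanged, the step from compound 3 to compound 4 being estimated at a step that the limit leaves unreadable from compound 3 to compound 4. Compound 4 is estimated at 150000 nM, with a range from 60000 nM to 400000 nM, most likely reported again as a limit.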

Compound 4, half-maximal cytotoxic concentration: > 50000 nM
Compound 4: no number, only a limit; the forecaster's own chance of this, stated with the estimate: 85%; the middle value is on the limit's open side.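

In this assay compound 4 gives > 50000 nM, a limit of the assay. Its steps from compound 1, compound 2 and compound 3 cannot be read, with limits standing at both ends of each. The compounds shown leave open whether any group on this carbonyl carbon would give a measurable half-maximal cytotoxic concentration.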